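The source may hold more compounds than are shown below. What is called first, only, known or untested is meant among the compounds shown, and "the series" means these compounds.

Measured so far in a functional assay on SK-MEL-28 cells (Homo sapiens) for inhibition, read by colorimetric assay and MTT assay, with a stated time of 72 h (a higher number here means a weaker inhibitor, a lower number a stronger inhibitor), are two compounds:

compound 1 `C=CCCCCOc1ccccc1-c1cnc(OCCC=C)n1C` gives 17000 nM
compound 2 `CCCCOc1ncc(-c2ccccc2OC)n1C` gives 82000 nM

Compound 2 has the higher of these two numbers, which makes it the weaker inhibitor of the pair, and its gap to compound 1 lies beyond the usual scatter of repeated measurements.

Compound 3 `CCCCCCOc1ncc(-c2ccccc2OC)n1C` has not been measured yet. Among the measured compounds shown here, its one change from compound 2 puts ethyl in place of hydrogen on a saturated chain carbon, four bonds along the chain from an oxygen on an aromatic ring and leaves the rest of the structure untouched. For the measured compounds named here, no measured pair isolates this change, so the evidence is thin. Compound 2 differs from compound 1 in more than one place, and compound 1 gives 17000 nM as the lower value, which is only a weak hint toward a lower number. The step of a 2.3-fold lower number from compound 2 to compound 3 (0.37 log units; beyond the scatter) is therefore expected to be modest and toward a lower number, perhaps not far beyond the scatter. Compound 3 is estimated at 35000 nM within an expected range of 12000 nM to 80000 nM when tested in this assay conditions.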

Compound 3, half-maximal inhibitory concentration: 43000 nM
For compound 3 the middle estimate is 1.2-fold (0.09 log units) below the measured one, and the stated range covers the measured number.
By their numbers in this assay, from the lowest: compound 1; then compounds 3 and 2 (each within the scatter of the next).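

Among the compounds shown here, the first comparison in which only one place differs comes from this assay and concerns ethyl in place of hydrogen on a saturated chain carbon, four bonds along the chain from an oxygen on an aromatic ring. This change gives a 1.9-fold lower number from compound 2 to compound 3 (0.28 log units; within the scatter) and so cannot be told apart from the ordinary variation between repeated measurements. At this position, then, adding these two carbons to the chain does not produce a clear change in the cell result, and nothing shown here offers an explanation for that outcome.

For the compounds shown here, what remains open is whether a group of another kind at this place, such as an amine or a carboxylic acid at the end of the chain, or a chain longer than the one in compound 3, would move the number clearly in either direction. Compound 1 differs from compound 2 and from compound 3 in more than one place, so the compounds shown do not reveal which of its structural differences matter in this assay where compound 1 gives 17000 nM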